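A few compounds are considered here, and "the series" means these few. Any claim that something is new, unique, unknown or untested is made for them only; others in the source may bear on it.

Compound 1, `Cn1nc(-c2ccccc2)nc1[S+](C)[O-]`: in a functional assay on the whole organism for antagonist activity, with Mus musculus as the target (a higher number here means that more compound is needed for the effect, a lower number that less compound is needed), compound 1 gives > 200 mg/kg, a limit of the assay.
Compound 2, `Cn1nc(-c2ccccc2)nc1S(C)(=O)=O`: in this assay compound 2 gives > 200 mg/kg, also a limit.
Compound 3, `Cn1nc([S+](C)[O-])nc1-c1ccccc1`: in this assay compound 3 gives > 200 mg/kg, again a limit.

From compound 1 to compound 2 the change is a group of 4 heavy atoms (1 carbon, 2 oxygen, 1 sulfur; no ring) in place of a group of 3 heavy atoms (1 carbon, 1 oxygen, 1 sulfur; no ring), on an aromatic carbon. Its effect is a step that the two limits leave unreadable from compound 1 to compound 2, since both values are limits (the limit of > 200 mg/kg in this assay, at which 3 of the 3 values shown sit). Compound 4, `Cn1nc(S(C)(=O)=O)nc1-c1ccccc1`, is not yet measured. It differs from compound 3 by a group of 4 heavy atoms (1 carbon, 2 oxygen, 1 sulfur; no ring) in place of a group of 3 heavy atoms (1 carbon, 1 oxygen, 1 sulfur; no ring), on an aromatic carbon; this is the same kind of change as that from compound 1 to compound 2, but the surroundings differ: there the new group sits next to the ring atom that bears a methyl group, here two ring bonds from it. How the core of compound 3 differs from that of compound 1 is not broken down here. For compound 4 the step from compound 3 is expected to be a step that the limit leaves unreadable from compound 3 to compound 4, resting on compound 1 and compound 2 both sitting at the limit (the limit of > 200 mg/kg in this assay, at which 3 of the 3 values shown sit). Compound 4 is estimated at 300 mg/kg, between 150 mg/kg and 1000 mg/kg, most likely reported as a limit.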

Compound 4, dose for half-maximal effect: > 200 mg/kg
Compound 4 gave a limit, no number; the forecaster's own chance of this, stated with the estimate: 85%; the middle value is on the limit's open side.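

Compound 4, like compound 3, gives only a limit, so the step between them cannot be read, and the same holds for compound 1 and compound 2. In this assay the compounds shown leave open how much of any of them is needed for the effect.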